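Moving the chlorine around the phenyl ring of a pyridine series

This account rests on a few compounds, and the source may have more. Where it says the series, first, only, none or still open, it means among the compounds named here.

Compound 2 `Clc1ccc(-c2cc(-c3cccs3)nc(-c3ccccc3Cl)c2)o1` gives 18500 nM in a functional assay on HeLa cells (Homo sapiens) for cytotoxicity, in the presence of a further agent that is not named here (a higher number here means a weaker inhibitor, a lower number a stronger inhibitor), the highest of the three numbers measured. Compound 1 `Clc1cccc(-c2cc(-c3ccc(Cl)o3)cc(-c3cccs3)n2)c1` gives 12800 nM, and compound 3 `Clc1ccc(-c2cc(-c3ccoc3)cc(-c3cccs3)n2)cc1` gives 5530 nM. Compound 4 `Clc1ccc(-c2cc(-c3ccc(Cl)o3)cc(-c3cccs3)n2)cc1` has not yet been measured; it differs from compound 2 by 4-chlorophenyl in place of 2-chlorophenyl on an aromatic carbon. For the measured compounds named here, the one measured step that bears on this is also a relocation of chlorine on the phenyl ring: a 1.4-fold higher number from compound 1 to compound 2 (0.16 log units; within the scatter). Compound 3, which also carries a 4-chlorophenyl group but a different furan, sits at the low end of the measured numbers. The expected step from compound 2 to compound 4 is therefore small, leaning toward a lower number, a 2.1-fold lower number from compound 2 to compound 4 (0.31 log units; beyond the scatter). Compound 4 is expected to give 9000 nM, between 3500 nM and 23000 nM.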

Compound 4, half-maximal inhibitory concentration: 21300 nM
Estimate against measurement, compound 4: 2.4-fold (0.37 log units) below; the range from low to high includes it.
By their numbers in this assay, from the lowest: compound 3; then compounds 1, 2 and 4 (each within the scatter of the next).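

In this assay the chlorine position on the phenyl ring makes no difference that can be read, with a 1.2-fold higher number from compound 2 to compound 4 (0.06 log units; within the scatter) and a 1.7-fold higher number from compound 1 to compound 4 (0.22 log units; within the scatter), so compounds 1, 2 and 4 all sit within the scatter of the next. The change that does register is on the furan, with a 3.9-fold higher number from compound 3 to compound 4 (0.59 log units; beyond the scatter) as 5-chlorofuran-2-yl replaces furan-3-yl. Nothing measured here offers a reason for either result.

Going by these compounds, what an amine or a carboxylic acid in place of the chlorine would do remains open. So does whether the furan step holds with the chlorine elsewhere on the phenyl ring.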